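Chloro for hydrogen on the aniline ring of compound 1

The source may report more compounds than this note shows. Statements on the series, on what has been measured and on what is new or still open speak of the compounds shown alone.

Of the compounds shown here, three that share one core have been tested in a functional assay on a subcellular fraction from brain (Rattus norvegicus) for inhibition, read by scintillation counting, with a stated time of 5 min; on this read-out lower numbers stand for stronger inhibition and higher numbers for weaker inhibition. Compound 1 `c1ccc(NC2=NCCC3(CCCCC3)S2)cc1` carries an unsubstituted phenyl ring, and in this assay compound 1 gives 63100 nM. Among the compounds with values here, compound 3 `Cc1ccc(NC2=NCCC3(CCCCC3)S2)cc1Cl` bears a methyl and a chloro on the ring, and compound 3 gives 89100 nM, a number within the scatter of the one for compound 1. Compound 2 `CCc1cccc(CC)c1NC1=NCCC2(CCCCC2)S1` has two ethyl groups on the ring, and compound 2 gives 7900 nM, the lowest of the three numbers and beyond the scatter from the other two. Among the three, compound 1 thus stands second highest, close to compound 3 and far from compound 2.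

Compound 4 `Clc1ccc(NC2=NCCC3(CCCCC3)S2)cc1` has not yet been measured. It differs from compound 1 by chloro in place of hydrogen on an aromatic carbon. Within the data shown here, the set gives no single-change step that isolates this change; compound 3, which also carries a chloro, sits within the scatter of compound 1. The step from compound 1 to compound 4 is therefore expected to be a 1.4-fold lower number from compound 1 to compound 4 (0.15 log units; within the scatter), small and not clearly beyond the scatter. For compound 4 the estimate in this assay is 45000 nM, with a range from 12000 nM to 140000 nM.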

Compound 4, half-maximal inhibitory concentration: 35500 nM
Beside the measured number, compound 4's estimate is 1.3-fold (0.10 log units) above it; the measured number falls inside the stated range.
By their numbers in this assay, from the lowest: compound 2; then compounds 4, 1 and 3 (each within the scatter of the next, the first and the last beyond it).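

In this assay, within the data shown here, the change gives a 1.8-fold lower number from compound 1 to compound 4 (0.25 log units; within the scatter) and so supplies the first single-change step in this set. At this place, on an aromatic carbon para to a large group, chloro in place of hydrogen does not separate compound 4 from compound 1 beyond the scatter. No measurement shown here offers an explanation for the size of this step.

On these data alone, it remains open whether an amine or a carboxylic acid at the same place would give a step beyond the scatter, or whether such a group would also stay within it. Among these compounds, the two ethyl groups of compound 2 also remain unresolved, since no single-change step connects that compound to compound 1 and the contribution of each ethyl group cannot be read.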